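Cyclohexyl aryl ureas: halogen changes and cytotoxicity

The source may report more compounds than this note shows. Statements on the series, on what has been measured and on what is new or still open speak of the compounds shown alone.

Compound 1 `O=C(Nc1cccc(Br)c1)N[C@H]1CC[C@H](Oc2ccc(F)cc2)CC1`: 6200 nM
Compound 2 `O=C(Nc1cccc(Cl)c1)N[C@H]1CC[C@H](Oc2ccc(F)cc2)CC1`: 5900 nM

In a functional assay on CRL2813 cells (Homo sapiens) for cytotoxicity, read by sulforhodamine B assay, with a stated time of 5 days (on this read-out lower numbers stand for stronger inhibition and higher numbers for weaker inhibition), compound 2 stands lowest of the two numbers, yet a 1.1-fold lower number from compound 1 to compound 2 (0.02 log units; within the scatter) lies within the scatter. Compound 3 `O=C(Nc1ccccc1I)N[C@H]1CC[C@H](Oc2ccc(F)cc2)CC1` differs from compound 2 by 2-iodophenyl in place of 3-chlorophenyl on an amide-type nitrogen. Among the compounds with values here, the only measured step, a 1.1-fold lower number from compound 1 to compound 2 (0.02 log units; within the scatter), exchanged one halogen for another on the same ring and shifted nothing; for a halogen at a new place on the ring no step is at hand. A number near that of compound 2 is therefore expected, with a 1.1-fold higher number from compound 2 to compound 3 (0.04 log units; within the scatter) taken as no change beyond the scatter and a wide range. Compound 3 is estimated at 6500 nM (range 2500 nM to 18000 nM).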

Compound 3, half-maximal inhibitory concentration: > 20000 nM
Compound 3: only a limit was reported (the forecaster's own chance of this, stated with the estimate: 10%); at least 3.0-fold (0.48 log units) between middle value and limit.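

In this assay, within the data shown here, the change from a halogen-bearing ring to 2-iodophenyl on the amide-type nitrogen is the first to move the number beyond the scatter: an at least 3.3-fold higher number from compound 2 to compound 3 (0.53 log units; beyond the scatter), and an at least 3.2-fold higher number from compound 1 to compound 3 (0.50 log units; beyond the scatter). The exchange of chloro for bromo on the same ring did not do this, so this position does not tolerate every halogen change alike. Compound 3 carries only a limit, so the full size of the step stays unknown: the limit of > 20000 nM in this assay, at which 1 of the 3 values shown sits.

Halogen and ring place change together here, so the compounds shown do not tell which of the two carries the step. 3-Iodophenyl and 2-chlorophenyl on the same nitrogen would separate them.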